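Methoxy in Place of Trifluoromethyl on the Urea Aryl Ring

The source may report more compounds than this note shows. Statements on the series, on what has been measured and on what is new or still open speak of the compounds shown alone.

Compound 1, `COc1ccc(NC(=O)Nc2cc(C)nc3ccccc23)cc1`, gives > 25000 nM in an ADME assay on BJ cells (Homo sapiens) for cytotoxicity, with a stated time of 72 h; on this read-out lower numbers stand for an effect already at smaller amounts and higher numbers for an effect only at larger amounts of compound.
Compound 2, `Cc1cc(NC(=O)Nc2ccccc2C(F)(F)F)c2ccccc2n1`, gives > 25000 nM in this assay.
Compound 3, `Cc1cc(NC(=O)Nc2cccnc2)c2ccccc2n1`, gives > 25000 nM in this assay.

Each of these three values is a limit of the assay rather than a measured number. Compound 2 therefore stands where every other value shown stands, with nothing to separate it from the rest: the limit of > 25000 nM in this assay, at which 3 of the 3 values shown sit.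

Compound 4, `COc1ccccc1NC(=O)Nc1cc(C)nc2ccccc12`, differs from compound 2 in one place: methoxy in place of trifluoromethyl on an aromatic carbon. Going by the values given here, no step between two measured compounds is available to gauge such a change, and all three measured compounds are alike at the limit. In this assay the expected step is a step that the limit leaves unreadable from compound 2 to compound 4, none beyond the scatter. Compound 4 is thus estimated at 30000 nM, between 10000 nM and 100000 nM, most likely reported again only as a limit.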

Compound 4, half-maximal effective concentration: > 25000 nM
Compound 4 ended at the assay's limit; the forecaster's own chance of this, stated with the estimate: 85%; the middle value is on the limit's open side.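

No step can be read from compound 2 to compound 4, as both values are limits of the assay rather than numbers: the limit of > 25000 nM in this assay, at which 4 of the 4 values shown sit.

The compounds shown leave open at what concentration any of them would show an effect in this assay, and whether methoxy and trifluoromethyl differ there at all.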